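The compounds below may be only part of what the source reports. "The series", "measured", "known", "first", "only" and "open" are said of these compounds alone.

Measured compounds:
compound 1 `CCCCCCNc1nc(SCc2ccc(C(F)(F)F)cc2)nc2ccccc12` — 24300 nM
compound 2 `Fc1ccc(Nc2nc(SCc3ccc(C(F)(F)F)cc3)nc3ccccc23)cc1` — 36300 nM

In a functional assay on MCF7 cells (Homo sapiens) for cytotoxicity, read by MTT assay, with a stated time of 72 h (on this read-out lower numbers stand for stronger inhibition and higher numbers for weaker inhibition), compound 2 gives 36300 nM and compound 1 gives 24300 nM. Among the compounds with values here, only two numbers exist, and the single measured step of a 1.5-fold higher number from compound 1 to compound 2 (0.17 log units; within the scatter) stays within the scatter, so compound 2 is not separated from compound 1 on this read-out.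

Compound 3 `COc1cc(Nc2nc(SCc3ccc(C(F)(F)F)cc3)nc3ccccc23)cc(OC)c1` differs from compound 2 by 3,5-dimethoxyphenyl in place of 4-fluorophenyl on a nitrogen on an aromatic ring. Within the data shown here, the one step that bears on this position, a 1.5-fold higher number from compound 1 to compound 2 (0.17 log units; within the scatter), exchanged an alkyl chain for an aryl group on the same nitrogen and moved the number by less than the scatter. Among the measured compounds shown here, no measured step exchanges one aryl group for another at that nitrogen, so nothing in the data points to a direction. Compound 3 is therefore expected to land near compound 2, with an expected step of a 1.2-fold lower number from compound 2 to compound 3 (0.08 log units; within the scatter) that does not exceed the scatter. For compound 3 the estimate is 30000 nM, with a range from 10000 nM to 90000 nM.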

Compound 3, half-maximal inhibitory concentration: 6990 nM
Estimate against measurement, compound 3: 4.3-fold (0.63 log units) above, and the stated range ends above it.
By their numbers in this assay, from the lowest: compound 3; then compounds 1 and 2 (each within the scatter of the next).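

In this assay, within the data shown here, the aryl group on this nitrogen is no longer neutral: 3,5-dimethoxyphenyl in place of 4-fluorophenyl gives a 5.2-fold lower number from compound 2 to compound 3 (0.72 log units; beyond the scatter), the first step at this position to clear the scatter. The same group also separates from the hexyl chain, with a 3.5-fold lower number from compound 1 to compound 3 (0.54 log units; beyond the scatter), so having an aryl group here is not enough in itself, since compound 2 carries one and stays unseparated from compound 1. Nothing available accounts for this difference.

From the compounds shown here alone, whether a 3-methoxyphenyl or a 3,5-dimethylphenyl group on the same nitrogen would keep the number of compound 3 remains open. Going by these compounds, it is also open whether the step would carry over to a core in which the 4-(trifluoromethyl)benzyl group on sulfur is replaced by a plain benzyl group.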